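Branched monoalkylamino replacements on a triazolopyrimidine series

The source may report more compounds than this note shows. Statements on the series, on what has been measured and on what is new or still open speak of the compounds shown alone.

Measured compounds in an assay on isolated protein for displacement of a labelled ligand from corticotropin-releasing factor receptor 1 (Homo sapiens); on this read-out higher numbers stand for weaker inhibition and lower numbers for stronger inhibition:
compound 1, `CCCN(CC1CC1)c1nc(C)nc2c(-c3ccc(Cl)cc3Cl)c(C)nn12`, 0.7 nM
compound 2, `CCOCC(COCC)Nc1nc(C)nc2c(-c3ccc(Cl)cc3Cl)c(C)nn12`, 6.2 nM
compound 3, `CCCCC(CC)Nc1nc(C)nc2c(-c3ccc(Cl)cc3Cl)c(C)nn12`, 1.6 nM

Compound 1 gives the lowest number of the three; compound 3 sits nearest, compound 2 furthest. Compound 4, `CCCC(CC)Nc1nc(C)nc2c(-c3ccc(Cl)cc3Cl)c(C)nn12`, is not yet measured. It differs from compound 1 in one place: (1-ethylbutyl)amino in place of (cyclopropylmethyl)(propyl)amino on an aromatic carbon. The closest measured step is a 2.3-fold higher number from compound 1 to compound 3 (0.36 log units; beyond the scatter), where a branched monoalkylamino group of similar shape, one carbon longer, likewise replaced the (cyclopropylmethyl)(propyl)amino group. The step of a 3.9-fold lower number from compound 2 to compound 3 (0.59 log units; beyond the scatter) shows that within the monoalkylamino compounds the 1-ethylpentyl chain gives the lower number. For compound 4 a modest move upward from compound 1 in this assay is therefore expected, of about a 2.1-fold higher number from compound 1 to compound 4 (0.33 log units; beyond the scatter). The estimate for compound 4 is 1.5 nM, with a range from 0.6 nM to 4 nM.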

Compound 4, inhibition constant: 1.2 nM
Estimate against measurement, compound 4: 1.3-fold (0.10 log units) above, and the stated range covers the measured number.
By their numbers in this assay, from the lowest: compounds 1, 4 and 3 (each within the scatter of the next, the first and the last beyond it); then compound 2.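

In this assay, the (1-ethylbutyl)amino group, with no ring and a hydrogen-bond donor, stays within the scatter of the (cyclopropylmethyl)(propyl)amino group (a 1.7-fold higher number from compound 1 to compound 4 (0.23 log units; within the scatter)), which the 1-ethylpentyl replacement did not. Taking the end methyl off the 1-ethylpentyl chain leaves a step within the scatter (a 1.3-fold lower number from compound 3 to compound 4 (0.12 log units; within the scatter)), while the ether-bearing chain stays clearly apart (a 5.2-fold lower number from compound 2 to compound 4 (0.71 log units; beyond the scatter)). On these data alone, a shorter 1-ethylpropyl chain or a cyclopentyl group on the nitrogen remains open. Nothing available explains these steps.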